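Stereochemical inversion of the hydroxycyclohexyl amine

The compounds below may be only part of what the source reports. "The series", "measured", "known", "first", "only" and "open" are said of these compounds alone.

Measured: compound 1 `N#Cc1cnc(NCc2cnccc2C(F)(F)F)cc1N[C@H]1C[C@H](O)C1`, compound 2 `N#Cc1cnc(NCc2cnccc2C(F)(F)F)cc1N[C@H]1CC[C@@H](O)CC1`.

In an assay on isolated protein for inhibition of protein kinase C delta type (Homo sapiens), read by TR-FRET, with a stated time of 2 h (a higher number here means a weaker inhibitor, a lower number a stronger inhibitor), compound 1 gives only a limit, > 10000 nM. In this assay compound 2 gives 4500 nM, the only number shown in the series. Among the compounds with values here, the step of an at least 2.2-fold lower number from compound 1 to compound 2 (0.34 log units; beyond the scatter) is the sole measured change, and it concerns ring size, not configuration, with compound 1 sitting at the limit of > 10000 nM in this assay, at which 1 of the 2 values shown sits.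

Compound 3 `N#Cc1cnc(NCc2cnccc2C(F)(F)F)cc1N[C@H]1CC[C@H](O)CC1` differs from compound 2 only as follows: the two compounds have the same atoms and bonds and differ only in configuration as drawn: 2 of 2 stereo elements differ (all stereocentres are inverted: mirror images); a stereocentre at a saturated ring carbon is drawn s in compound 2 and r in compound 3; a stereocentre at a saturated ring carbon is drawn s in compound 2 and r in compound 3. Within the data shown here, no measured step bears on such an inversion, so no shift beyond the scatter is expected, no change at the digits printed from compound 2 to compound 3 (within the scatter). Compound 3 is estimated at 4500 nM, range 1400 nM to 14000 nM.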

Compound 3, half-maximal inhibitory concentration: 6500 nM
Compound 3: middle estimate off by 1.4-fold (0.16 log units), on the low side, and the stated range covers the measured number.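

In this assay, inverting both drawn stereocentres of the 4-hydroxycyclohexyl group gives a 1.4-fold higher number from compound 2 to compound 3 (0.16 log units; within the scatter), so this configuration does not separate the two compounds at this position. The same ring change read with compound 3 gives an at least 1.5-fold lower number from compound 1 to compound 3 (0.18 log units; that floor lies within the scatter), a weaker reading than the step to compound 2. Compound 1 remains a limit, so the full size of either ring step is unknown: the limit of > 10000 nM in this assay, at which 1 of the 3 values shown sits.

Open, as far as these compounds go, is whether the hydroxy group matters at all. An amine or a carboxylic acid in its place on the cyclohexyl ring would test this.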